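A few compounds are considered here, and "the series" means these few. Any claim that something is new, unique, unknown or untested is made for them only; others in the source may bear on it.

Measured in a functional assay on HeLa cells (Homo sapiens) for inhibition, read by trypan blue exclusion, with a stated time of 72 h; a lower number here means a stronger inhibitor of growth, a higher number a weaker inhibitor of growth:
- Compound 1 `CCCn1c(-c2ccc(O)cc2)c(C)c2ccccc21`: > 20000 nM
- Compound 2 `Cc1c(-c2ccc(OC(=O)c3c[nH]cn3)cc2)[nH]c2ccccc12`: > 20000 nM

Both readings are limits of the assay and not numbers, so neither compound can be placed on a scale against the other. Compound 2 stands at the limit of > 20000 nM in this assay, at which 2 of the 2 values shown sit. Compound 3 `Cc1c(-c2ccc(O)cc2)[nH]c2ccccc12` follows from compound 2 by removing the ester acyl group, with hydrogen in place of (1H-imidazol-4-yl)carbonyl on an oxygen on an aromatic ring. This leaves a free hydroxy group. The same hydroxy group also stands on compound 1, whose reading > 20000 nM is likewise a limit. Within the data shown here, no measured step shows what this change does in this assay, so the expectation is for no shift beyond the scatter, and a reading that is again only a limit would not be a surprise. The expected a number no higher from compound 2 to compound 3 (the limit leaves the size open) is correspondingly small. For compound 3 the estimated value is 20000 nM, with an expected range of 8000 nM to 40000 nM.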

Compound 3, concentration for 50% growth inhibition: > 20000 nM
Compound 3 was reported as a limit (the forecaster's own chance of this, stated with the estimate: 70%); the middle value lies on the limit itself.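

In this assay compound 3 gives > 20000 nM, which is a limit of the assay. The steps to compound 3 from compound 2 and from compound 1 therefore cannot be read. The compounds shown leave open whether the (1H-imidazol-4-yl)carbonyl or the propyl group changes growth inhibition at all in this assay.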